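Hydroxy for sulfanyl on the two-ring core

This account rests on a few compounds, and the source may have more. Where it says the series, first, only, none or still open, it means among the compounds named here.

Measured so far in an assay for inhibition of Dihydrofolate reductase (Homo sapiens); on this read-out higher numbers stand for higher potency (the scale is a negative logarithm) and lower numbers for lower potency:
compound 1 `CC1CCc2nc(N)nc(O)c2C1` gives 4.26
compound 2 `Nc1nc2ccccc2c(=O)[nH]1` gives 4.31
compound 3 `Nc1nc(S)nc2ccccc12` gives 3.72

Compound 3 stands lowest of the three numbers. Its nearest neighbour is compound 1, whose value lies higher by a margin beyond the scatter, and compound 2 lies higher still, also beyond the scatter. The step taken next keeps the core of compound 3 and alters one group: hydroxy in place of sulfanyl on an aromatic carbon The product is compound 4 `Nc1nc(O)nc2ccccc12`, not yet measured in this assay.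

For the measured compounds named here, no step between measured compounds is available as a guide. Compound 3 is the only carrier of the sulfanyl group and sits below both other compounds, each of which carries oxygen on its core. On that basis a step upward in this assay is expected from compound 3 to compound 4, of a size beyond the scatter, a number 0.53 log units higher from compound 3 to compound 4 (beyond the scatter). For compound 4 the estimated value in this assay is 4.25, with a range from 3.85 to 4.65.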

Compound 4, logarithm of the reciprocal of the active concentration, log(1/C): 4.02
Beside the measured number, compound 4's estimate is 0.23 log units above it; measured number inside the range.
By their numbers in this assay, from the lowest: compounds 3, 4, 1 and 2 (each within the scatter of the next, the first and the last beyond it).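

For the compounds shown here, this is the first pair that differs in one place only, and it isolates the exchange on the aromatic carbon between two ring nitrogen atoms. In this assay, hydroxy in place of sulfanyl at this position gives a number 0.30 log units higher from compound 3 to compound 4 (within the scatter), so this pair does not separate the two groups beyond the scatter, and the single-atom exchange of sulfur for oxygen has no resolved effect on this read-out. No measured evidence bears on the reason for this result.

Still open, on these data alone, is whether an amine or a methoxy group on the same aromatic carbon would read apart from hydroxy and sulfanyl in this assay. Also open, as far as these compounds go, is whether the same exchange would read alike with a chlorine or a methyl group elsewhere on the shared core.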